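A few compounds are considered here, and "the series" means these few. Any claim that something is new, unique, unknown or untested is made for them only; others in the source may bear on it.

Measured so far in a functional assay on LNCaP cells (Homo sapiens) for cytotoxicity, read by MTT assay, with a stated time of 72 h; a lower number here means a stronger inhibitor, a higher number a weaker inhibitor:
Compound 1 `CC(=O)n1cc(/C=C(/C(=O)O)c2ccccc2)c2cc(OCc3ccccc3)ccc21`: in this assay compound 1 gives only a limit, > 100000 nM.
Compound 2 `COc1ccccc1/C(=C\c1cn(C(C)=O)c2ccc(OCc3ccccc3)cc12)C(=O)O`: compound 2 gives 48500 nM.
Compound 3 `CC(=O)n1cc(/C=C(/C(=O)O)c2ccc(Cl)cc2)c2cc(OCc3ccccc3)ccc21`: compound 3 gives only a limit, > 100000 nM.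

Compound 3 thus sits at the limit, as does compound 1 (the limit of > 100000 nM in this assay, at which 2 of the 3 values shown sit). The unmeasured compound 4 `COc1ccc(OC)c(/C(=C\c2cn(C(C)=O)c3ccc(OCc4ccccc4)cc23)C(=O)O)c1` differs from compound 3 by 2,5-dimethoxyphenyl in place of 4-chlorophenyl on a double-bonded chain carbon bound to a carbonyl carbon and a double-bonded chain carbon. Among the measured compounds shown here, two measured steps bear on it. The step of an at least 2.0-fold lower number from compound 1 to compound 2 (0.31 log units; beyond the scatter) shows methoxy in place of hydrogen on an aromatic carbon bringing the number off the limit; the step of an at least 2.0-fold higher number from compound 2 to compound 3 (0.31 log units; beyond the scatter) shows 4-chlorophenyl in place of 2-methoxyphenyl taking it back up. With 2,5-dimethoxyphenyl entering, a step down from the limit is expected, an at least 2.5-fold lower number from compound 3 to compound 4 (0.39 log units; beyond the scatter). Compound 4 is therefore estimated at 40000 nM, within 15000 nM to 100000 nM.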

Compound 4, half-maximal inhibitory concentration: 44100 nM
For compound 4 the middle estimate is 1.1-fold (0.04 log units) below the measured one, and the stated range covers the measured number.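

In this assay, 2,5-dimethoxyphenyl on the double-bonded chain carbon keeps the number off the limit, with an at least 2.2-fold lower number from compound 3 to compound 4 (0.35 log units; beyond the scatter) and an at least 2.2-fold lower number from compound 1 to compound 4 (0.35 log units; beyond the scatter). The further methoxy adds no readable gain over the 2-methoxyphenyl of compound 2, with a 1.1-fold lower number from compound 2 to compound 4 (0.04 log units; within the scatter). Compound 1 and compound 3 remain at a limit of the assay, so these two steps have only a lower bound: the limit of > 100000 nM in this assay, at which 2 of the 4 values shown sit.

From the compounds shown here alone, whether an amine or a hydroxyl in place of methoxy on this phenyl ring would bring the number lower remains open. Going by these compounds, the full size of the steps from compound 1 and compound 3 also remains open.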